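The compounds below may be only part of what the source reports. "The series", "measured", "known", "first", "only" and "open" are said of these compounds alone.

Compound 1 `O=C1N=C(N2N=C(c3ccccc3)CC2c2ccccc2O)S/C1=C1/C(=O)Nc2ccccc21` and compound 2 `O=C1N=C(N2N=C(c3ccccc3)CC2c2ccc(Cl)cc2)S/C1=C1/C(=O)Nc2ccccc21` share one core and differ only on a saturated ring carbon. In a functional assay on cells (Cancer cell lines, Homo sapiens) for cytotoxicity, read by sulforhodamine B assay, with a stated time of 48 h (a higher number here means a weaker inhibitor of growth, a lower number a stronger inhibitor of growth), compound 1 gives 4220 nM, while compound 2 gives 390 nM, a step of an 11-fold lower number from compound 1 to compound 2 (1.03 log units; beyond the scatter). Compound 2 therefore holds the lowest of the two numbers. Compound 3 `O=C1N=C(N2N=C(c3ccc4ccccc4c3)CC2c2ccc(Cl)cc2)S/C1=C1/C(=O)Nc2ccccc21` differs from compound 2 by naphthalen-2-yl in place of phenyl on a carbon with a double bond to nitrogen. Among the measured compounds shown here, the single measured step, an 11-fold lower number from compound 1 to compound 2 (1.03 log units; beyond the scatter), concerns a different position, the 4-chlorophenyl carbon, and does not bear on this change; for compound 3 no step beyond the scatter is expected in this assay. Compound 3 is estimated at 400 nM, within 130 nM to 1300 nM. The expected step is a 1.0-fold higher number from compound 2 to compound 3 (0.01 log units; within the scatter).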

Compound 3, concentration for total growth inhibition: 70300 nM
Estimate against measurement, compound 3: 180-fold (2.24 log units) below, and the stated range ends below it.
By their numbers in this assay, from the lowest: compound 2; then compound 1; then compound 3.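

The carbon with a double bond to nitrogen, which the earlier pair left untouched, proves far from indifferent to its group. In this assay, adding a second aromatic ring of carbon only, with no hydrogen-bond donor or acceptor entering, gives a 180-fold higher number from compound 2 to compound 3 (2.26 log units; beyond the scatter). Nothing available here accounts for this loss of growth inhibition. Still open, from the compounds shown here alone, is whether a methyl group or a 4-methoxyphenyl group on this carbon would stay close to compound 2, and whether naphthalen-2-yl would have the same effect alongside 2-hydroxyphenyl.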